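A few compounds are considered here, and "the series" means these few. Any claim that something is new, unique, unknown or untested is made for them only; others in the source may bear on it.

Compound 1 `CC#C[C@@H](Cc1nnn[nH]1)c1ccc(OCc2ccc3scc(-c4cc(OCCOC)ccc4C)c3c2)cc1`: 26 nM
Compound 2 `CC#C[C@@H](Cc1nnn[nH]1)c1ccc(OCc2ccc3scc(-c4ccc(OCCC(C)(C)O)cc4C)c3c2)cc1`: 4 nM

In a functional assay on cells for agonist activity at Free fatty acid receptor 1 (Rattus norvegicus), read by FLIPR and calcium flux (a higher number here means that more compound is needed for the effect, a lower number that less compound is needed), compound 1 gives 26 nM, the highest of the two numbers available. Compound 2 gives 4 nM, a gap that lies beyond the usual scatter, so compound 1 is the weaker of the two measured compounds. The step from compound 1 to compound 3 `CC#C[C@@H](Cc1nnn[nH]1)c1ccc(OCc2ccc3scc(C4CC4)c3c2)cc1` is cyclopropyl in place of 5-(2-methoxyethoxy)-2-methylphenyl on an aromatic carbon. Here the whole substituted aromatic ring is removed and only a small ring remains on the shared core. Going by the values given here, no measured pair shows a change of this kind, so the expectation rests on the two measured values and on the size of the removed piece alone. Compound 3 is expected to need more compound than compound 1, a step of a 9.6-fold higher number from compound 1 to compound 3 (0.98 log units; beyond the scatter) in this assay that is expected to reach well beyond the scatter. For compound 3 the estimated value is 250 nM, with a range from 50 nM to 1500 nM.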

Compound 3, half-maximal effective concentration: 239 nM
Compound 3: the middle estimate sits 1.0-fold (0.02 log units) above what was measured; measured number inside the range.
By their numbers in this assay, from the lowest: compound 2; then compound 1; then compound 3.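

Going by these compounds alone, the only single-place change at hand gives, in this assay, a 9.2-fold higher number from compound 1 to compound 3 (0.96 log units; beyond the scatter) when cyclopropyl stands in place of 5-(2-methoxyethoxy)-2-methylphenyl. This shows that the position two ring bonds from the ring sulfur responds to what it carries, and that the number rises beyond the scatter when the substituent shrinks from 12 heavy atoms to 3. Yet compound 3 still gives a measurable number without the six-membered aromatic ring, and nothing measured here accounts for the size of this step.

A single step cannot separate the loss of the aromatic ring from the loss of the methyl group or the 2-methoxyethoxy chain. A plain phenyl group or a 2-methylphenyl group would divide that step, while a cyclohexyl ring or a longer alkyl chain would test whether an aromatic ring is needed here at all.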